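This account rests on a few compounds, and the source may have more. Where it says the series, first, only, none or still open, it means among the compounds named here.

Among the compounds with values here, compound 3, `CC(C)Nc1nnc(SCC(=O)N(Cc2cccc([N+](=O)[O-])c2)c2ccc(F)cc2)s1`, gives 86.1% in an assay on isolated protein for inhibition of Amine oxidase [flavin-containing] A (Homo sapiens), read by fluorescence and Amplex Red, with a stated time of 30 min, tested at 10 uM (a lower number here means a weaker effect, a higher number a stronger effect of the compound at the concentration tested), the highest of the three numbers measured so far. Compound 2, `COCCNc1nnc(SCC(=O)N(Cc2cccc([N+](=O)[O-])c2)c2ccc(F)cc2)s1`, gives 80.6% in this assay, and the step of a number 5.5 percentage points higher from compound 2 to compound 3 (within the scatter) stays within the scatter. Compound 1, `CC(C)CNc1nnc(SCC(=O)N(Cc2cccc([N+](=O)[O-])c2)c2ccc(F)cc2)s1`, gives 72.6% in this assay; the step of a number 13.5 percentage points higher from compound 1 to compound 3 (beyond the scatter) is the only one in the set that goes beyond the scatter, and the step of a number 8 percentage points higher from compound 1 to compound 2 (within the scatter) again stays within it.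

Compound 4, `CCNc1nnc(SCC(=O)N(Cc2cccc([N+](=O)[O-])c2)c2ccc(F)cc2)s1`, is the next member of the series. It differs from compound 3 in one place: hydrogen in place of methyl on a saturated chain carbon bound to a nitrogen on an aromatic ring and a saturated chain carbon. Within the data shown here, of the measured steps, the one from compound 1 to compound 3 bears most directly on this, since it also shortened the chain on the nitrogen of the shared core by one carbon and gave a modest gain beyond the scatter; the step from compound 2 to compound 3, a change of the same chain, stayed within the scatter. With compound 3 already near the upper part of the range, the step of a number 1.1 percentage points lower from compound 3 to compound 4 (within the scatter) is expected to be small, with no change beyond the scatter expected. Compound 4 is therefore estimated at 85% in this assay, with a range from 72% to 95%.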

Compound 4, a percentage reported as inhibition, at one concentration (the size of the read-out at that concentration, not a potency): 74.1%
Compound 4: middle estimate off by 10.9 percentage points, on the high side, and the stated range covers the measured number.
By their numbers in this assay, from the lowest: compounds 1, 4, 2 and 3 (each within the scatter of the next, the first and the last beyond it).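

Trimming isopropyl to ethyl on the nitrogen of the shared core is not a neutral change, since a number 12 percentage points lower from compound 3 to compound 4 (beyond the scatter) in this assay shows that one methyl at this place can shift the read-out beyond the scatter. The earlier gain on going from isobutyl to isopropyl therefore does not reflect a shorter chain alone, for a number 1.5 percentage points higher from compound 1 to compound 4 (within the scatter) leaves the ethyl and isobutyl compounds within the scatter of each other, and a number 6.5 percentage points lower from compound 2 to compound 4 (within the scatter) does the same for the ethyl and 2-methoxyethyl compounds, so only isopropyl stands beyond the scatter from ethyl and isobutyl, while compound 2 does not separate from it. No supporting information is available that could explain this difference.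

On these data alone, what remains open is whether the result depends on the branched carbon itself, which a cyclopropyl or a tert-butyl on this nitrogen would help to test. An unsubstituted amine or a methylamino group at the same place would show how far the chain can be cut back.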